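From Methyl to Methoxy on the Benzyl Ring

The compounds below may be only part of what the source reports. "The series", "measured", "known", "first", "only" and "open" are said of these compounds alone.

Compound 1, `Clc1cccc(-n2ncnc2NCc2ccccc2)c1Cl`, 47.9 nM
Compound 2, `Cc1ccccc1CNc1ncnn1-c1cccc(Cl)c1Cl`, 20.9 nM

In a functional assay for antagonist activity at P2X purinoceptor 7 (Homo sapiens), read by FLIPR and calcium flux (a lower number here means a stronger inhibitor, a higher number a weaker inhibitor), compound 1 gives 47.9 nM, and compound 2 gives 20.9 nM. For the measured compounds named here, compound 2 has the lower of the two numbers, and its only neighbour is compound 1, with the step of a 2.3-fold lower number from compound 1 to compound 2 (0.36 log units; beyond the scatter) lying beyond the scatter.

Compound 3, `COc1ccccc1CNc1ncnn1-c1cccc(Cl)c1Cl`, has not yet been measured. It differs from compound 2 by methoxy in place of methyl on an aromatic carbon of a six-membered aromatic ring of carbon only, ortho to a large group. Going by the values given here, only one measured step touches this carbon, a 2.3-fold lower number from compound 1 to compound 2 (0.36 log units; beyond the scatter), which shows that a methyl there is worth a modest gain over hydrogen. Among the compounds with values here, no measured pair tells what a methoxy does in the same place, so the expectation for compound 3 rests on the methyl alone and is wide. Compound 3 is expected to stay close to compound 2, with a step of a 1.4-fold higher number from compound 2 to compound 3 (0.16 log units; within the scatter) that need not exceed the scatter. The estimate for compound 3 is 30 nM, with a range of 10 nM to 90 nM.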

Compound 3, half-maximal inhibitory concentration: 57.5 nM
Compound 3: middle estimate off by 1.9-fold (0.28 log units), on the low side, and the stated range covers the measured number.
By their numbers in this assay, from the lowest: compound 2; then compounds 1 and 3 (each within the scatter of the next).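

In this assay, the gain from the methyl does not carry over to a methoxy on the same aromatic carbon, where methoxy in place of methyl gives a 2.8-fold higher number from compound 2 to compound 3 (0.44 log units; beyond the scatter) and the two groups are clearly separated. For the compounds shown here, measured against hydrogen, the methoxy gives a 1.2-fold higher number from compound 1 to compound 3 (0.08 log units; within the scatter), so compound 1 and compound 3 cannot be told apart, and of the three compounds only the one bearing the methyl stands apart from the others. This place on the ring therefore responds to the identity of the group and not simply to the presence of one, although nothing available here explains the difference between methyl and methoxy.

The compounds shown leave open whether the gain is particular to the methyl or would also appear with an ethyl group, a chlorine atom or a fluorine atom on this carbon. They also leave open whether a hydroxyl group or an amine in the same place would follow the methyl or the methoxy, and whether either of these two groups would give the same result on another carbon of this ring.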